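A few compounds are considered here, and "the series" means these few. Any claim that something is new, unique, unknown or untested is made for them only; others in the source may bear on it.

In a functional assay on A549 cells (Homo sapiens) for antiproliferative activity, read by MTT assay, with a stated time of 48 h (on this read-out higher numbers stand for weaker inhibition and lower numbers for stronger inhibition), compound 3 (`N#Cc1ncn(Cc2ccc(F)cc2)c1/N=C/c1ccc([N+](=O)[O-])cc1`) gives 2020 nM as the lowest of three numbers, against compound 2 (`COc1ccc(/C=N/c2c(C#N)ncn2-c2ccc(F)cc2)cc1`) at 17100 nM and compound 1 (`N#Cc1ncn(-c2ccc(F)cc2)c1/N=C/c1ccc([N+](=O)[O-])cc1`) at 18100 nM as the higher two. Compound 4 (`COc1ccc(/C=N/c2c(C#N)ncn2Cc2ccc(F)cc2)cc1`) differs from compound 3 by a single change (methoxy in place of nitro on an aromatic carbon) with methoxy in place of nitro on an aromatic carbon. Going by the values given here, one measured step bears on this directly: a 1.1-fold lower number from compound 1 to compound 2 (0.02 log units; within the scatter) is the same exchange, carried out with 4-fluorophenyl on the aromatic nitrogen. The other step (a 9.0-fold lower number from compound 1 to compound 3 (0.95 log units; beyond the scatter)) is 4-fluorobenzyl in place of 4-fluorophenyl and does not test this exchange. In this assay no step beyond the scatter is therefore expected, though this rests on a single pair. The expected change is a 1.0-fold lower number from compound 3 to compound 4 (0.00 log units; within the scatter) on that basis. Compound 4 is estimated at 2000 nM (range 800 nM to 5000 nM).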

Compound 4, half-maximal inhibitory concentration: 4620 nM
For compound 4 the middle estimate is 2.3-fold (0.36 log units) below the measured one, within the range that was stated.
By their numbers in this assay, from the lowest: compound 3; then compound 4; then compounds 2 and 1 (each within the scatter of the next).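

On the 4-fluorobenzyl core, methoxy in place of nitro gives a step beyond the scatter in this assay (a 2.3-fold higher number from compound 3 to compound 4 (0.36 log units; beyond the scatter)), unlike the same exchange on the 4-fluorophenyl core, yet the two steps do not clearly differ: the same change on two cores in this assay, a 1.1-fold lower number (0.02 log units; within the scatter) from compound 1 to compound 2 and a 2.3-fold higher number (0.36 log units; beyond the scatter) from compound 3 to compound 4, 2.4-fold (0.38 log units) apart, within the scatter of two such steps. 4-Fluorobenzyl in place of 4-fluorophenyl also lowers the number with methoxy present (a 3.7-fold lower number from compound 2 to compound 4 (0.57 log units; beyond the scatter)), and this benefit is therefore not confined to the nitro compounds: the same change on two cores in this assay, a 9.0-fold lower number (0.95 log units; beyond the scatter) from compound 1 to compound 3 and a 3.7-fold lower number (0.57 log units; beyond the scatter) from compound 2 to compound 4, 2.4-fold (0.38 log units) apart, within the scatter of two such steps.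

Going by these compounds, whether an amine or a carboxylic acid in this place would follow methoxy or nitro remains open. So does the effect of a longer chain between the aromatic nitrogen and the 4-fluorophenyl ring.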